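The source may report more compounds than this note shows. Statements on the series, on what has been measured and on what is new or still open speak of the compounds shown alone.

Of the compounds shown here, two built on a shared core have so far been tested in a functional assay on HL-60 cells (Homo sapiens) for inhibition, read by MTT assay, with a stated time of 72 h; a higher number here means a weaker inhibitor, a lower number a stronger inhibitor. Compound 1 `Cc1nc(-c2ccc(F)cc2)c(C(=O)N2CCN(c3ccc(C(=O)C(C)C)cc3)CC2)o1` was reported as "not active" (no number reported), and no number accompanies that entry. Within the data shown here, compound 2 `Cc1nc(-c2ccccc2)c(C(=O)N2CCN(c3cccc(C#N)c3)CC2)o1` gives 39.6 nM in this assay and therefore stands as the only compound here with a measured number; the other entry offers no figure to set beside it. Compound 3 `COc1cccc(N2CCN(C(=O)c3oc(C)nc3-c3ccccc3)CC2)c1` is the next compound to be tested. It differs from compound 2 in a single place: methoxy in place of cyano on an aromatic carbon. Among the measured compounds shown here, no pair of measured compounds shows this change, so nothing here tells how large its effect is. Both groups carry one hydrogen-bond acceptor and no donor, and the swap is expected to bring a modest loss of potency, a step of a 2.3-fold higher number from compound 2 to compound 3 (0.36 log units; beyond the scatter), with wide uncertainty. Compound 3 is estimated at 90 nM, within a range of 20 nM to 500 nM.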

Compound 3, half-maximal inhibitory concentration: 34.8 nM
The estimate for compound 3 lay 2.6-fold (0.41 log units) above the measured number; the range from low to high includes it.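

In this assay, putting methoxy in place of cyano on this aromatic carbon gives a 1.1-fold lower number from compound 2 to compound 3 (0.06 log units; within the scatter). This first direct comparison therefore shows no real difference between the 3-cyanophenyl and 3-methoxyphenyl groups: the potency of the series holds with either one at this place on the ring. No measurement is available here to explain how two such different groups come to give matching results.

As far as these compounds go, only these two groups can be compared at this place, so it remains open whether an amine, a carboxylic acid or a longer chain such as butoxy would be tolerated as well. Compound 1 differs from both compounds in more than one place and has no number, so it cannot show which of its changes matters.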